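Piperidin-1-yl in Place of (4-Ethylphenyl)amino: An Estimate

The compounds below may be only part of what the source reports. "The series", "measured", "known", "first", "only" and "open" are said of these compounds alone.

Of the compounds shown here, three built on one shared core have been tested in a functional assay on MCF7 cells (Homo sapiens) for inhibition, read by sulforhodamine B assay; on this read-out lower numbers stand for stronger inhibition and higher numbers for weaker inhibition. Compound 1 `CCCc1ccc(NC2=CC(=O)c3nc4n(c3C2=O)[C@H]2OC[C@@H](O)[C@H]2OC4)cc1` gives 4660 nM in this assay. Compound 3 `CCc1ccc(NC2=CC(=O)c3nc4n(c3C2=O)[C@H]2OC[C@@H](O)[C@H]2OC4)cc1` gives 960 nM. For compound 2 `Cc1ccc(NC2=CC(=O)c3c(nc4n3[C@H]3OC[C@@H](O)[C@H]3OC4)C2=O)cc1` the assay reports only a limit rather than a number, > 4000 nM, which is the limit of > 4000 nM in this assay, at which 1 of the 3 values shown sits. Among the compounds with values here, of the two actual numbers, compound 3 has the lower one, and the single measured step, a 4.9-fold lower number from compound 1 to compound 3 (0.69 log units; beyond the scatter), is the only guide to how this core responds to a change at the amine-bearing carbon.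

Compound 4 `O=C1C=C(N2CCCCC2)C(=O)c2c1nc1n2[C@H]2OC[C@@H](O)[C@H]2OC1` differs from compound 3 in this way: piperidin-1-yl in place of (4-ethylphenyl)amino on a double-bonded ring carbon. Within the data shown here, no measured step covers such a change: the one step known shortens a chain while keeping the aromatic ring and its hydrogen-bond donor, whereas here the whole (4-ethylphenyl)amino group, with its aromatic ring and donor, leaves and a non-aromatic piperidin-1-yl ring enters. The expectation therefore rests only on the size of this change, and a step toward weaker inhibition, beyond the scatter, is expected: a 5.2-fold higher number from compound 3 to compound 4 (0.72 log units; beyond the scatter). Compound 4 is thus estimated to give 5000 nM in this assay, within a range from 1000 nM to 25000 nM.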

Compound 4, half-maximal inhibitory concentration: > 8000 nM
Compound 4 ended at the assay's limit; the forecaster's own chance of this, stated with the estimate: 40%; middle value at least 1.6-fold (0.20 log units) away from the limit.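

In this assay, putting piperidin-1-yl in place of (4-ethylphenyl)amino on the double-bonded ring carbon gives an at least 8.3-fold higher number from compound 3 to compound 4 (0.92 log units; beyond the scatter), so this change weakens inhibition at least as much as the chain change seen earlier. Within the data shown here, compounds 1 and 3 differ only in a chain on the aromatic ring, whereas this result is the first to test replacing the whole group at this position. Compound 4 has only a limit, so the true size of the step remains unknown: the limit of > 8000 nM in this assay, at which 1 of the 4 values shown sits.

The change removes the aromatic ring and the hydrogen-bond donor together, so the compounds shown cannot tell which loss matters. A cyclohexylamino group would keep the donor without the aromatic ring, and an N-methyl-(4-ethylphenyl)amino group would keep the aromatic ring without the donor.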